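A few compounds are considered here, and "the series" means these few. Any claim that something is new, unique, unknown or untested is made for them only; others in the source may bear on it.

Three compounds sharing one core have been examined in an assay on isolated protein for binding affinity to vitamin D3 receptor (Homo sapiens), read by fluorescence polarization, tested at 1 uM; a higher number here means more inhibition at the concentration tested (going by the name of the read-out), a lower number less inhibition. Compound 1 `CCCC(O)(C#Cc1ccc(C(CC)(CC)C2=CN(CC)C(C(=O)NCCN(CC)CC)C2)cc1C)CCC` gives 51.1%, compound 3 `CCN(CC)CCNC(=O)C1CC(C(CC)(CC)c2ccc(/C=C/C(O)(CC)CC)c(C)c2)=CN1CC` gives 65.5%, and compound 2 `CCN(CC)CCNC(=O)C1CC=C(C(CC)(CC)c2ccc(C#CC(C)(C)O)c(C)c2)N1CC` gives 60.2%, the second highest of the three, within the scatter of both neighbours. For the measured compounds named here, the only single-point step among them, a number 14.4 percentage points higher from compound 1 to compound 3 (beyond the scatter), bears on the present question, since compound 4 `CCN(CC)CCNC(=O)C1CC=C(C(CC)(CC)c2ccc(/C=C/C(C)(O)CC)c(C)c2)N1CC` differs from compound 2 in the same region: a group of 7 heavy atoms (6 carbon, 1 oxygen; no ring) in place of a group of 6 heavy atoms (5 carbon, 1 oxygen; no ring), on an aromatic carbon. An increase of similar kind, though not necessarily of the same size, is therefore expected, a number 8.8 percentage points higher from compound 2 to compound 4 (within the scatter). Compound 4 is estimated at 69%, with a range from 56% to 81%.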

Compound 4, a percentage reported as inhibition, at one concentration (the size of the read-out at that concentration, not a potency): 68.9%
The estimate for compound 4 lay 0.1 percentage points above the measured number; measured number inside the range.
By their numbers in this assay, from the lowest: compounds 1, 2, 3 and 4 (each within the scatter of the next, the first and the last beyond it).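

At this position, on an aromatic carbon ortho to a methyl group and para to a large group, replacing 3-hydroxy-3-methylbut-1-yn-1-yl with the larger group carrying a double bond gives a number 8.7 percentage points higher from compound 2 to compound 4 (within the scatter) in this assay. The direction matches a number 14.4 percentage points higher from compound 1 to compound 3 (beyond the scatter), now on the differently arranged core of compound 2, but this step alone does not establish a change.

From the compounds shown here alone, whether an amine in place of the hydroxyl, or a saturated ethylene link, would hold the number remains open. Nothing available accounts for the step.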